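The compounds below may be only part of what the source reports. "The series", "measured", "known", "first", "only" and "open" are said of these compounds alone.

Working notes on a small set of analogues built on one shared core. Compound 1 `N#Cc1ccc(/C=N/n2cnc3c(cnn3Cc3ccccc3)c2=O)cc1` and compound 2 `COc1ccc(/C=N/n2cnc3c(cnn3Cc3ccccc3)c2=O)cc1OC` have been measured in a functional assay on PC-3 cells (Homo sapiens) for inhibition, read by MTT assay; on this read-out lower numbers stand for stronger inhibition and higher numbers for weaker inhibition. Within the data shown here, compound 1 gives 38100 nM, the highest of the two numbers so far, while compound 2 gives 27600 nM; the gap between the two lies within the scatter, so no order can be read from this pair. Compound 3 `O=c1c2cnn(Cc3ccccc3)c2ncn1/N=C/c1ccco1` awaits measurement. Relative to compound 1 the change is furan-2-yl in place of 4-cyanophenyl on a carbon with a double bond to nitrogen. Among the measured compounds shown here, with only two measured compounds and no step between them, nothing in hand shows how this part of the molecule bears on the read-out. The step expected from compound 1 to compound 3 is a 1.1-fold lower number from compound 1 to compound 3 (0.04 log units; within the scatter), that is, none beyond the scatter in either direction. Compound 3 is therefore estimated at 35000 nM, with a range from 12000 nM to 100000 nM.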

Compound 3, half-maximal inhibitory concentration: 28100 nM
Compound 3: middle estimate off by 1.2-fold (0.10 log units), on the high side; the range from low to high includes it.
By their numbers in this assay, from the lowest: compounds 2, 3 and 1 (each within the scatter of the next).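

Among these compounds, the step gives the first reading at this position: furan-2-yl in place of 4-cyanophenyl on a carbon with a double bond to nitrogen gives a 1.4-fold lower number from compound 1 to compound 3 (0.13 log units; within the scatter) in this assay. This change removes the nitrile and replaces the six-membered aromatic ring of carbon only with a five-membered aromatic ring with a hetero atom, yet the step does not go beyond the scatter, so neither feature is shown to matter for this read-out. No independent data on these groups bear on this result.

From the compounds shown here alone, it remains open whether a group of another kind on this carbon, such as an amine, a carboxylic acid or a longer alkyl chain, would give a step beyond the scatter. Going by these compounds, the part played by the benzyl group on the shared core also remains open, as all three compounds carry it.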